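A few compounds are considered here, and "the series" means these few. Any claim that something is new, unique, unknown or untested is made for them only; others in the source may bear on it.

Compound 1 `C/N=C(/NC)Nc1nc(-c2ccc(OC)cc2)c(-c2ccc(OC)cc2)s1` is the only one of the three measured compounds with a number: in a functional assay with Oryctolagus cuniculus as the target (a higher number here means a weaker inhibitor, a lower number a stronger inhibitor), compound 1 gives 970 nM. Compound 2 `COc1ccc(-c2nc(CN)sc2-c2ccc(OC)cc2)cc1` reaches only a limit of the assay, > 100 nM. Compound 3 `COc1ccc(-c2nc(/C=C/C(=O)O)sc2-c2ccc(OC)cc2)cc1` likewise reaches only a limit of the assay, > 100 nM. The steps among them are therefore not readable: a step that the limit leaves unreadable from compound 1 to compound 2, a step that the limit leaves unreadable from compound 1 to compound 3, and a step that the two limits leave unreadable from compound 2 to compound 3; this follows from the limit of > 100 nM in this assay, at which 2 of the 3 values shown sit.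

Compound 4 `COc1ccc(-c2nc(C3=CCN(C)CC3)sc2-c2ccc(OC)cc2)cc1` differs from compound 1 at the same carbon of the shared core that was varied in compounds 2 and 3: a group of 7 heavy atoms (6 carbon, 1 nitrogen; one six-membered non-aromatic ring with 1 hetero atom) in place of a group of 6 heavy atoms (3 carbon, 3 nitrogen; no ring), on an aromatic carbon. Both measured replacements at that carbon bear on this step, but neither gives a size or a direction, so nothing beyond the scatter can be expected from them. Compound 4 is therefore estimated to sit near compound 1, with a wide range: 900 nM, between 150 nM and 6000 nM. The expected step is a 1.1-fold lower number from compound 1 to compound 4 (0.03 log units; within the scatter).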

Compound 4, half-maximal inhibitory concentration: < 10 nM
Compound 4 gave a limit, no number (the forecaster's own chance of this, stated with the estimate: 40%); middle value at least 90-fold (1.95 log units) away from the limit.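

In this assay compound 4 reaches a limit, < 10 nM, and not a number. This carbon of the shared core therefore does more than the earlier limits could show: with the six-membered non-aromatic ring in place of the group with no ring, there is an at least 97-fold lower number from compound 1 to compound 4 (1.98 log units; beyond the scatter), a large step. The same ring also separates clearly from the aminomethyl and 2-carboxyethenyl groups at this carbon, with an at least 10-fold lower number from compound 2 to compound 4 (1.00 log units; beyond the scatter) and an at least 10-fold lower number from compound 3 to compound 4 (1.00 log units; beyond the scatter), so the choice of group here matters in this assay.

How far these steps truly reach stays open, since the value of compound 4 is only a limit: the limit of < 10 nM in this assay, at which 1 of the 4 values shown sits. The compounds shown also do not tell whether the step belongs to the ring, its double bond or its methyl group, as a saturated piperidine or a ring with a free secondary amine could.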